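Shortening the diethylamino chain on the thieno-pyrimidine series

A few compounds are considered here, and "the series" means these few. Any claim that something is new, unique, unknown or untested is made for them only; others in the source may bear on it.

Compound 3 `CCN(CC)CCCNc1nc(-c2ccc(NC(=O)Nc3ccc(F)cc3)cc2)nc2c(Cl)c(Cl)sc12` gives 1630 nM in a functional assay on MDA-MB-231 cells (Homo sapiens) for cytotoxicity, read by MTT assay, with a stated time of 72 h; on this read-out higher numbers stand for weaker inhibition and lower numbers for stronger inhibition. Its number is the highest of the three measured, but the steps of a 1.7-fold higher number from compound 1 to compound 3 (0.22 log units; within the scatter) and a 1.3-fold higher number from compound 2 to compound 3 (0.12 log units; within the scatter) both lie within the scatter, so it cannot be set apart from compound 1 `CN(C)CCCNc1nc(-c2ccc(NC(=O)Nc3ccc(F)cc3)cc2)nc2c(Cl)c(Cl)sc12` at 980 nM or compound 2 `CN(C)CCNc1nc(-c2ccc(NC(=O)Nc3ccc(F)cc3)cc2)nc2c(Cl)c(Cl)sc12` at 1240 nM. Compound 4 `CCN(CC)CCNc1nc(-c2ccc(NC(=O)Nc3ccc(F)cc3)cc2)nc2c(Cl)c(Cl)sc12` carries diethylamino in place of (diethylamino)methyl on a saturated chain carbon, two bonds along the chain from a nitrogen on an aromatic ring. The same chain shortening within the dimethylamino pair reads a 1.3-fold higher number from compound 1 to compound 2 (0.10 log units; within the scatter), a step within the scatter. He therefore expects no step beyond the scatter for compound 4, with perhaps a slight rise, as a 1.2-fold higher number from compound 3 to compound 4 (0.09 log units; within the scatter). His estimate for compound 4 in this assay is 2000 nM, ranging from 1000 nM to 4000 nM.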

Compound 4, half-maximal inhibitory concentration: 1130 nM
Beside the measured number, compound 4's estimate is 1.8-fold (0.25 log units) above it, within the range that was stated.
By their numbers in this assay, from the lowest: compounds 1, 4, 2 and 3 (each within the scatter of the next).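

Compound 4 completes the set of both chain lengths with both amines, and the chain shortening with diethylamino reads a 1.4-fold lower number from compound 3 to compound 4 (0.16 log units; within the scatter) in this assay, so at this position it stays within the scatter, as it did with dimethylamino. Diethylamino in place of dimethylamino on the shorter chain reads a 1.1-fold lower number from compound 2 to compound 4 (0.04 log units; within the scatter), and the change in both places together reads a 1.2-fold higher number from compound 1 to compound 4 (0.06 log units; within the scatter). The amine change, read at both chain lengths, gives no difference that can be told apart: the same change on two cores in this assay, a 1.7-fold higher number (0.22 log units; within the scatter) from compound 1 to compound 3 and a 1.1-fold lower number (0.04 log units; within the scatter) from compound 2 to compound 4, 1.8-fold (0.26 log units) apart, within the scatter of two such steps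

All these steps lie within the scatter, so the compounds shown leave open whether the amine or chain at this position matters at all in this assay. As far as these compounds go, a ring amine such as morpholine or piperidine, or a longer chain such as a 4-(diethylamino)butyl group, remains open.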